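This account rests on a few compounds, and the source may have more. Where it says the series, first, only, none or still open, it means among the compounds named here.

Compound 2, whose structure is `COc1cc(C(=O)N2CCN(C(=O)c3cc(OC)c(OC)c(OC)c3)C(COC(=O)C3CCCCC3)C2)cc(OC)c1OC`, is an ester in which a cyclohexyl group sits on the carbonyl carbon; in a functional assay (Oryctolagus cuniculus) for inhibition of platelet-activating factor receptor (Cavia porcellus) (on this read-out higher numbers stand for weaker inhibition and lower numbers for stronger inhibition), compound 2 gives 290 nM. Its nearest measured neighbour is compound 1, the structure `CCCCCC(=O)OCC1CN(C(=O)c2cc(OC)c(OC)c(OC)c2)CCN1C(=O)c1cc(OC)c(OC)c(OC)c1`, which carries a pentyl group at the same position; in this assay compound 1 gives 290 nM. Among the compounds with values here, the single step between them, no change at the digits printed from compound 1 to compound 2 (within the scatter), lies within the scatter, so exchanging the pentyl chain for the six-membered carbon ring left the read-out where it was.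

Compound 3, the structure `COc1cc(C(=O)N2CCN(C(=O)c3cc(OC)c(OC)c(OC)c3)C(COC(=O)CC(C)(C)C)C2)cc(OC)c1OC`, has not yet been measured in this assay. It differs from compound 2 only at the ester: neopentyl in place of cyclohexyl on a carbonyl carbon. Within the data shown here, the one step that bears on this change is the pentyl-to-cyclohexyl step from compound 1 to compound 2, which was flat. On that basis the step of a 1.0-fold higher number from compound 2 to compound 3 (0.01 log units; within the scatter) is expected to stay within the scatter as well. For compound 3 the estimate in this assay is therefore 300 nM, with a range from 150 nM to 600 nM.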

Compound 3, half-maximal inhibitory concentration: 120 nM
Beside the measured number, compound 3's estimate is 2.5-fold (0.40 log units) above it; the whole stated range lies above it.
By their numbers in this assay, from the lowest: compound 3; then compounds 1 and 2 (each within the scatter of the next).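

This ester position is not indifferent to the group on the carbonyl carbon: in this assay neopentyl in place of cyclohexyl gives a 2.4-fold lower number from compound 2 to compound 3 (0.38 log units; beyond the scatter) as its result, and tert-butyl in place of butyl on a saturated chain carbon bound to a carbonyl carbon gives a 2.4-fold lower number from compound 1 to compound 3 (0.38 log units; beyond the scatter) in the same direction. The absence of a ring does not account for this by itself, since the pentyl group of compound 1 has no ring either and compound 1 stands level with compound 2, so among these three esters only the neopentyl group, with its tert-butyl end, goes with the lower number. Nothing available here explains why the number falls with this change.

On these data alone, it remains open whether the lower number depends on the exact distance of the tert-butyl unit from the carbonyl carbon, as a tert-butyl group placed directly on that carbon or a longer chain ending in tert-butyl would show. As far as these compounds go, it is equally open how this position would respond to a phenyl ring, an amine or a carboxylic acid, or whether an amide could take the place of the ester.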